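The compounds below may be only part of what the source reports. "The series", "measured", "known", "first", "only" and "open" are said of these compounds alone.

Of the compounds shown here, three have numbers so far in a functional assay on MDA-MB-231 cells (Homo sapiens) for antiproliferative activity, read by MTT assay, with a stated time of 48 h (on this read-out lower numbers stand for stronger inhibition and higher numbers for weaker inhibition), and no two of them differ in one place only. Compound 1 (`C=CS(=O)(=O)N1CCN(c2ncnc3ccc(-c4ccccc4)cc23)CC1`) has the highest number, with 47900 nM as its reading. Compound 2 (`C=CS(=O)(=O)N1CCN(c2nc(OC[C@H]3CCCN3C)nc3sc(-c4ccc(N5CCN(C)CC5)cc4)cc23)CC1`) has the lowest, with 760 nM as its reading. Compound 3 (`CN1CCN(c2ccc(-c3cc4c(N5CCN(S(=O)(=O)C6CC6)CC5)ncnc4s3)cc2)CC1`) lies in the middle, with 11500 nM as its reading. Its gaps to compound 1 and compound 2 both lie beyond the scatter, and the gap to compound 1 is the smaller.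

Next in line is compound 4 (`CN1CCN(c2ccc(-c3cc4c(N5CCN(C(=O)Nc6cccc(F)c6)CC5)ncnc4s3)cc2)CC1`), which has (3-fluorophenyl)carbamoyl in place of cyclopropylsulfonyl on an amine nitrogen in a ring and otherwise matches compound 3. Going by the values given here, no measured pair shows what a swap at this place does, so any expectation in this assay rests on thin ground. A modest move toward stronger inhibition seems the likelier outcome, with a wide margin on either side. The expected size of the change is a 2.3-fold lower number from compound 3 to compound 4 (0.36 log units; beyond the scatter) in this estimate. For compound 4 the estimated value is 5000 nM, with an expected range from 1200 nM to 20000 nM across repeat measurements.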

Compound 4, half-maximal inhibitory concentration: 13200 nM
Compound 4: the middle estimate sits 2.6-fold (0.42 log units) below what was measured; the measured number falls inside the stated range.
By their numbers in this assay, from the lowest: compound 2; then compounds 3 and 4 (each within the scatter of the next); then compound 1.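

In this assay, going by these compounds alone, the swap of cyclopropylsulfonyl for (3-fluorophenyl)carbamoyl on the amine nitrogen in a ring gives a 1.1-fold higher number from compound 3 to compound 4 (0.06 log units; within the scatter), the first readable step at this position. Compound 3 and compound 4 cannot be told apart on this read-out, even though the entering group is larger, carries a six-membered aromatic ring in place of a three-membered non-aromatic ring, and brings a hydrogen-bond donor where the leaving group has none; for this one pair, then, those differences come with no separation in the numbers, and the observation extends no further than these two compounds. No supporting data are available to explain this result.

As far as these compounds go, whether the same swap gives a comparable step on the core of compound 2 remains open, as that compound differs from compound 3 in more than one place. Also open is what a small acetyl group, a basic aminoalkyl chain or a chain ending in a carboxylic acid would do on this ring nitrogen, since the two groups shown cover only a narrow part of what this position could hold.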